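The source may hold more compounds than are shown below. What is called first, only, known or untested is meant among the compounds shown, and "the series" means these compounds.

Of the compounds shown here, three built on one shared core have been measured in a functional assay for inhibition of nuclear factor NF-kappa-B complex (Homo sapiens); a higher number here means a weaker inhibitor, a lower number a stronger inhibitor. Compound 1 `COc1ccc2c(c1)OC(c1cc(OC)c(OC)c(OC)c1)C(C(=O)OCCc1ccccc1)=C2` gives 16200 nM. Compound 2 `CCCCNC(=O)C1=Cc2ccc(OC)cc2OC1c1cc(OC)c(OC)c(OC)c1` carries butylamino where compound 1 carries phenethyloxy; in this assay compound 2 gives 25500 nM, and that change is a 1.6-fold higher number from compound 1 to compound 2 (0.20 log units; within the scatter). Compound 3 `COc1ccc2c(c1)OC(c1cc(OC)c(OC)c(OC)c1)C(C(=O)O)=C2` bears a free carboxy group, and for compound 3 this assay reports only a limit, > 50000 nM (the limit of > 50000 nM in this assay, at which 1 of the 3 values shown sits). Compound 3 therefore stands at a limit rather than at a number: the step to it from the ester is an at least 3.0-fold higher number from compound 1 to compound 3 (0.48 log units; beyond the scatter), and from the amide an at least 1.9-fold higher number from compound 2 to compound 3 (0.29 log units; that floor lies within the scatter).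

Compound 4 `COc1ccc2c(c1)OC(c1cc(OC)c(OC)c(OC)c1)C(C(=O)N(C)C)=C2` has not yet been measured. It differs from compound 3 by dimethylamino in place of hydroxy on a carbonyl carbon. Both measured steps that put a hydroxy in this place moved the number to the limit or beyond; going the other way, from hydroxy to an amine, is expected to bring the number back down by roughly the size of those steps, most likely to somewhere near compound 2. Compound 4 is expected to come out at 30000 nM, within 12000 nM to 60000 nM. That expectation corresponds to an at least 1.6-fold lower number from compound 3 to compound 4 (0.22 log units; that floor lies within the scatter), although a limit cannot be ruled out.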

Compound 4, half-maximal inhibitory concentration: > 50000 nM
Compound 4: a limit, no number (the forecaster's own chance of this, stated with the estimate: 35%); at least 1.6-fold (0.22 log units) between middle value and limit.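

In this assay, having an amide on this carbonyl carbon does not by itself give a readable number: compound 2, with butylamino, has one, while compound 4, with dimethylamino, reaches only a limit. Dimethylamino gives an at least 3.0-fold higher number from compound 1 to compound 4 (0.48 log units; beyond the scatter) against phenethyloxy, and an at least 1.9-fold higher number from compound 2 to compound 4 (0.29 log units; that floor lies within the scatter) against butylamino, so only the first of these floors clears the scatter. The step from compound 3 to compound 4 cannot be read, since both sit at a limit and not at a number: the limit of > 50000 nM in this assay, at which 2 of the 4 values shown sit.

As far as these compounds go, how far compound 3 and compound 4 lie past that limit stays unknown. Also open, from the compounds shown here alone, is whether a readable number depends on the chain or on the amide hydrogen, which a methylamino group or a longer chain such as hexylamino on this carbonyl carbon could help to separate.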